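The source may hold more compounds than are shown below. What is called first, only, known or untested is meant among the compounds shown, and "the series" means these compounds.

The measured compounds and their values:

compound 1, `CC(=O)c1cc(-c2ccccc2)cc2cc(-c3ccc(F)cc3)[nH]c12`; in a functional assay on MCF7 cells (Homo sapiens) for cytotoxicity, read by MTT assay, with a stated time of 2 days, tested at 10 uM (a lower number here means a stronger effect, a higher number a weaker effect of the compound at the concentration tested), compound 1 gives 91.9%.
compound 2, `CC(=O)c1cc(-c2ccc(F)cc2)cc2cc(-c3ccc(F)cc3)[nH]c12`; in this assay compound 2 gives 90.6%.
compound 3, `CC(=O)c1cc(/C=C/c2ccccc2)cc2cc(-c3ccc(F)cc3)[nH]c12`; in this assay compound 3 gives 69.5%.

Compound 3 stands lowest of the three numbers, which here means the strongest effect at the concentration tested: a number 22.4 percentage points lower from compound 1 to compound 3 (beyond the scatter) and a number 21.1 percentage points lower from compound 2 to compound 3 (beyond the scatter), both beyond the scatter, while compound 1 and compound 2 sit within the scatter of each other.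

Compound 4, `CC(=O)c1cc(/C=C/c2ccc(F)cc2)cc2cc(-c3ccc(F)cc3)[nH]c12`, differs from compound 3 in one place: fluoro in place of hydrogen on an aromatic carbon. Among the compounds with values here, the only measured step of the same kind is the one in which the same exchange was made on a different ring of the shared core: a number 1.3 percentage points lower from compound 1 to compound 2 (within the scatter), a change that stayed within the scatter. Within the data shown here, nothing among the measured compounds suggests that adding fluoro in this position moves the number appreciably, so no step beyond the scatter is expected from compound 3 to compound 4 in this assay; the expected step is a number 1.5 percentage points lower from compound 3 to compound 4 (within the scatter).

On that basis compound 4 is estimated to give 68% in this assay, with a range from 55% to 82%.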

Compound 4, a percentage reported as activity, at one concentration (the size of the read-out at that concentration, not a potency): 67.4%
Estimate against measurement, compound 4: 0.6 percentage points above, within the range that was stated.
By their numbers in this assay, from the lowest: compounds 4 and 3 (each within the scatter of the next); then compounds 2 and 1 (each within the scatter of the next).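

In this assay, the exchange of hydrogen for fluoro, para to a large group, now has a second reading on a different group of the shared core, and it stays small on both: the same change on two cores in this assay, a number 1.3 percentage points lower (within the scatter) from compound 1 to compound 2 and a number 2.1 percentage points lower (within the scatter) from compound 3 to compound 4, 0.8 percentage points apart, within the scatter of two such steps. The step of a number 2.1 percentage points lower from compound 3 to compound 4 (within the scatter) shows that fluoro on the 2-phenylethenyl group leaves the number where it was, just as it did on the phenyl group. The separation between the ethenyl-linked compounds and those with a directly attached ring also persists once fluoro is present on both, with a number 23.2 percentage points lower from compound 2 to compound 4 (beyond the scatter) and a number 24.5 percentage points lower from compound 1 to compound 4 (beyond the scatter), so across these four compounds the ethenyl link goes with the lower numbers and fluoro does not.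

Fluoro is the only group shown in place of that hydrogen, so it remains open whether a methoxy group, an amine or a carboxylic acid there would shift the number. It is also open whether a saturated two-carbon chain or a longer chain in place of the ethenyl link would keep the lower number, and a single tested concentration gives no potency for any of these compounds.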